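The source may hold more compounds than are shown below. What is called first, only, known or untested is meant among the compounds shown, and "the series" means these compounds.

Measured in a functional assay on VCaP cells (Homo sapiens) for antiproliferative activity, read by propidium iodide staining, with a stated time of 96 h; a lower number here means a stronger inhibitor, a higher number a weaker inhibitor:
compound 1, `CC(O)(CSc1ccc(C(F)(F)F)cc1)C(=O)Nc1ccc(S(F)(F)(F)(F)F)cc1`: 24800 nM
compound 2, `CC(O)(CSc1ccc(OC(F)(F)F)cc1)C(=O)Nc1ccc(S(F)(F)(F)(F)F)cc1`: 16000 nM
compound 3, `CC(O)(COc1cccc(C(F)(F)F)c1)C(=O)Nc1cccc(S(F)(F)(F)(F)F)c1`: 22500 nM

Compound 1 and compound 2 share one core and differ in a single place: trifluoromethoxy in place of trifluoromethyl on an aromatic carbon. In this assay this change gave a 1.6-fold lower number from compound 1 to compound 2 (0.19 log units; within the scatter). Compound 3 is built on a different core, and the difference between the two cores is not broken down here; the values of compound 3 and compound 1 lie within the scatter of each other.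

Compound 4, `CC(O)(COc1cccc(OC(F)(F)F)c1)C(=O)Nc1cccc(S(F)(F)(F)(F)F)c1`, has not yet been measured. It differs from compound 3 by trifluoromethoxy in place of trifluoromethyl on an aromatic carbon. Going by the values given here, this is the same kind of change as the one between compound 1 and compound 2, though not the same, since in compound 1 the group sits para to a large group and in compound 3 meta to a large group. Among the compounds with values here, the step expected from compound 3 to compound 4 in this assay is a 1.5-fold lower number from compound 3 to compound 4 (0.18 log units; within the scatter), resting on the one earlier instance, a 1.6-fold lower number from compound 1 to compound 2 (0.19 log units; within the scatter), which stayed within the scatter. Compound 4 is therefore estimated to give 15000 nM in this assay, with a likely range from 7000 nM to 35000 nM.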

Compound 4, half-maximal inhibitory concentration: 28600 nM
Beside the measured number, compound 4's estimate is 1.9-fold (0.28 log units) below it; measured number inside the range.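

In this assay, placing trifluoromethoxy where trifluoromethyl stood on the core of compound 3 gave a 1.3-fold higher number from compound 3 to compound 4 (0.10 log units; within the scatter). The two steps point in opposite directions, yet they do not differ beyond what two such steps can scatter, so the change behaved alike on the two cores as far as can be told: the same change on two cores in this assay, a 1.6-fold lower number (0.19 log units; within the scatter) from compound 1 to compound 2 and a 1.3-fold higher number (0.10 log units; within the scatter) from compound 3 to compound 4, 2.0-fold (0.29 log units) apart, within the scatter of two such steps This does not show that the change has a real effect of any direction or size on either core, since each step lies within the scatter, nor does it show that the two cores respond differently, and with only two instances it sets no rule for other cores in the series.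

The compounds shown leave open whether a different group on that aromatic carbon, such as a nitrile or an amine, would move the number beyond the scatter. They also leave open how much each difference between the two cores contributes, as no pair shown separates those differences.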